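A Sulfonyl Substituent Swap Between Two Weak Inhibitors

A few compounds are considered here, and "the series" means these few. Any claim that something is new, unique, unknown or untested is made for them only; others in the source may bear on it.

Two sulfonamides set the scene. Compound 1 `Cc1ccccc1S(=O)(=O)Nc1ccc(-c2nc3ccccc3o2)cc1` and compound 2 `O=S(=O)(Nc1ccc2oc(-c3ccccc3)nc2c1)c1cccs1` were both tested in an assay on cells for inhibition of HSP60/HSP10 (Homo sapiens), with a stated time of 60 min; on this read-out higher numbers stand for weaker inhibition and lower numbers for stronger inhibition. In this assay compound 1 gives 85000 nM, and compound 2 gives 90000 nM. For the measured compounds named here, the two numbers lie within the usual scatter of each other, so compound 2 cannot be set apart from compound 1 on these figures; both stand as weak inhibitors, and there is no measured step between compounds that differ in a single place.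

Compound 3 `CCc1ccc(S(=O)(=O)Nc2ccc3oc(-c4ccccc4)nc3c2)cc1` is the unmeasured partner of compound 2. It differs in one place: 4-ethylphenyl in place of thiophen-2-yl on a sulfonyl sulfur. The shared core and the sulfonamide link are kept; only the group on the sulfonyl sulfur changes.

Going by the values given here, with no measured step of this kind to lean on, the author expects the change from compound 2 to compound 3 to give a step of a 1.1-fold lower number from compound 2 to compound 3 (0.05 log units; within the scatter) in this assay, that is, none beyond the scatter. For compound 3 the estimated value in this assay is 80000 nM, with a range from 30000 nM to 200000 nM.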

Compound 3, half-maximal inhibitory concentration: > 100000 nM
Compound 3: a limit, no number; the forecaster's own chance of this, stated with the estimate: 25%; middle value at least 1.2-fold (0.09 log units) from the limit.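

For the compounds shown here, the swap of thiophen-2-yl for 4-ethylphenyl on a sulfonyl sulfur supplies the first measured step between compounds that differ in one place in this assay: an at least 1.1-fold higher number from compound 2 to compound 3 (0.04 log units; that floor lies within the scatter). Compound 3 gives > 100000 nM, which is a limit of the assay and not a number. The change therefore brings no stronger inhibition, a point the earlier compounds could not show, but only a floor can be read for the step, and its true size stays unknown because the read-out for compound 3 ends at a limit: the limit of > 100000 nM in this assay, at which 1 of the 3 values shown sits.

The compounds shown leave open whether any group on the sulfonyl sulfur can bring inhibition well below the level of compound 2, for instance a phenyl group carrying an amine or a carboxylic acid in place of 4-ethylphenyl. They also leave open whether a change elsewhere than on the sulfonyl sulfur, in the shared core or at the sulfonamide nitrogen, would shift the read-out in this assay by more than the usual scatter.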